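Ethyl on the Ring Nitrogen of Compound 3

A few compounds are considered here, and "the series" means these few. Any claim that something is new, unique, unknown or untested is made for them only; others in the source may bear on it.

Compound 3 `Fc1ccc2nc(-c3cccnc3)[nH]c2c1` gives 1990 nM in an assay on V79 cells for inhibition of cytochrome P450 11B1, mitochondrial (Homo sapiens), read by HTRF, with a stated time of 1 h (on this read-out higher numbers stand for weaker inhibition and lower numbers for stronger inhibition), the highest of the three numbers measured. For the measured compounds named here, compound 1 `Clc1ccc2nc(-c3cccnc3)n(C3CC3)c2c1` gives 477 nM and compound 2 `N#Cc1ccc2nc(-c3cccnc3)n(C3CC3)c2c1` gives 374 nM, both beyond the scatter below compound 3, while the one measured step, a 1.3-fold lower number from compound 1 to compound 2 (0.11 log units; within the scatter), stays within the scatter. Compound 4 `CCn1c(-c2cccnc2)nc2ccc(F)cc21` differs from compound 3 by ethyl in place of hydrogen on an aromatic nitrogen. Going by the values given here, no measured step bears directly on this change: compounds 1 and 2 carry a cyclopropyl group on the aromatic nitrogen but also differ from compound 3 elsewhere, so their lower numbers offer only a loose hint. The step of a 3.6-fold lower number from compound 3 to compound 4 (0.56 log units; beyond the scatter) is therefore expected to be moderate and downward. Compound 4 is estimated at 550 nM, within a range from 180 nM to 1700 nM.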

Compound 4, half-maximal inhibitory concentration: 2100 nM
Compound 4: the middle estimate sits 3.8-fold (0.58 log units) below what was measured; measured number above the stated range.
By their numbers in this assay, from the lowest: compounds 2 and 1 (each within the scatter of the next); then compounds 3 and 4 (each within the scatter of the next).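

In this assay, ethyl on the aromatic nitrogen of compound 3 gives a step within the scatter (a 1.1-fold higher number from compound 3 to compound 4 (0.02 log units; within the scatter)). For the compounds shown here, this is the first direct reading at this position, and it shows that, with the rest of compound 3 unchanged, ethyl and hydrogen cannot be told apart there. No measured evidence accounts for this result. Still open, going by these compounds, is how a longer chain such as propyl, a benzyl group or an aminoethyl group would read on this nitrogen, and whether ethyl would read the same with chloro or cyano in place of fluoro.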